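The source may hold more compounds than are shown below. What is called first, only, known or untested is meant among the compounds shown, and "the series" means these compounds.

Compound 1 `CC(=O)Oc1ccccc1C(=O)O[C@H]1CO[C@H]2[C@@H]1OC[C@H]2OC(=O)c1ccccc1` is the least stable of the three measured compounds in an ADME assay on a cell-free system (plasma, Homo sapiens) for metabolic stability, with Plasma (Rattus norvegicus) as the target, read by HPLC, at pH 7.4 (a lower number here means that the compound disappears faster, a higher number that the compound lasts longer), giving 0.0107 h. Compound 2 `CC(=O)Nc1cccc(C(=O)O[C@@H]2CO[C@H]3[C@@H]2OC[C@@H]3OC(=O)c2ccccc2OC(C)=O)c1` gives 0.0583 h in this assay, and compound 3 `CC(=O)Oc1ccccc1C(=O)O[C@H]1CO[C@H]2[C@@H]1OC[C@H]2OC(=O)c1ccccc1CO[N+](=O)[O-]` gives 0.0533 h. Both departures from compound 1 lengthen the half-life by a similar margin: a 5.4-fold higher number from compound 1 to compound 2 (0.74 log units; beyond the scatter), and a 5.0-fold higher number from compound 1 to compound 3 (0.70 log units; beyond the scatter). Between the two substituted compounds there is no real difference, since a 1.1-fold lower number from compound 2 to compound 3 (0.04 log units; within the scatter).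

Compound 4 `CC(=O)Oc1ccccc1C(=O)O[C@H]1CO[C@H]2[C@@H]1OC[C@H]2OC(=O)c1ccc(CO[N+](=O)[O-])cc1` differs from compound 1 in one place: (nitrooxy)methyl in place of hydrogen on an aromatic carbon. Going by the values given here, the nearest precedent is compound 3, where the same group enters at a different aromatic carbon and the half-life rose by a 5.0-fold higher number from compound 1 to compound 3 (0.70 log units; beyond the scatter). The step to compound 2, with a different group, was of the same size. On that basis the half-life of compound 4 is expected to lie well above that of compound 1, with a step of about a 4.2-fold higher number from compound 1 to compound 4 (0.62 log units; beyond the scatter) in this assay. The estimate for compound 4 in this assay is therefore 0.045 h, with a range from 0.015 h to 0.13 h.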

Compound 4, half-life: 0.04 h
Compound 4: the middle estimate sits 1.1-fold (0.05 log units) above what was measured; measured number inside the range.
By their numbers in this assay, from the lowest: compound 1; then compounds 4, 3 and 2 (each within the scatter of the next).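

In this assay, (nitrooxy)methyl on the aromatic carbon para to a large group also lengthens the half-life of compound 1 (a 3.7-fold higher number from compound 1 to compound 4 (0.57 log units; beyond the scatter)), so the gain is not tied to the single ring position seen in compound 3. Moving the group leaves no readable difference (a 1.3-fold lower number from compound 3 to compound 4 (0.12 log units; within the scatter)), and replacing 3-acetamidophenyl with 4-((nitrooxy)methyl)phenyl leaves none either (a 1.5-fold lower number from compound 2 to compound 4 (0.16 log units; within the scatter)). Nothing available accounts for these half-lives or for the similar size of the steps.

The compounds shown leave open whether a simple hydroxymethyl, an amine or a longer chain carrying the nitrooxy group at this ring position would give a similar half-life. They also leave open how acetamido would behave para to the large group, since it appears only in compound 2.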